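Triazole in place of alkyne on a longer ester chain

A few compounds are considered here, and "the series" means these few. Any claim that something is new, unique, unknown or untested is made for them only; others in the source may bear on it.

Compound 1 `C#CCCCCOC(=O)/C=C/c1ccc(OC(C)=O)c(OC(C)=O)c1` and compound 2 `C#CCCCCCCCCOC(=O)/C=C/c1ccc(OC(C)=O)c(OC(C)=O)c1` share one core and differ by hex-5-yn-1-yl in place of ethynyl on a saturated chain carbon, four bonds along the chain from an oxygen next to a carbonyl group. In an assay on isolated protein for inhibition of Polyunsaturated fatty acid 5-lipoxygenase (Homo sapiens), read by HPLC, with a stated time of 15 min (a higher number here means a weaker inhibitor, a lower number a stronger inhibitor), compound 1 gives only a limit, > 10000 nM. Compound 2 likewise gives only a limit, > 10000 nM. The step that the two limits leave unreadable from compound 1 to compound 2 stays unreadable because of the limit of > 10000 nM in this assay, at which 2 of the 3 values shown sit. Compound 3 `CC(=O)Oc1ccc(/C=C/C(=O)OCCCCc2cnnn2CCCO)cc1OC(C)=O` is reached from compound 1 by 1-(3-hydroxypropyl)-1H-1,2,3-triazol-5-yl in place of ethynyl on a saturated chain carbon, four bonds along the chain from an oxygen next to a carbonyl group, and in this assay compound 3 gives 7600 nM, a step of an at least 1.3-fold lower number from compound 1 to compound 3 (0.11 log units; that floor lies within the scatter). Compound 4 `CC(=O)Oc1ccc(/C=C/C(=O)OCCCCCCCCc2cnnn2CCCO)cc1OC(C)=O` is reached from compound 2 by 1-(3-hydroxypropyl)-1H-1,2,3-triazol-5-yl in place of ethynyl on a saturated chain carbon, eight bonds along the chain from an oxygen next to a carbonyl group, the same kind of change, set eight bonds along the chain from an oxygen next to a carbonyl group rather than four bonds. Beside that earlier step, the expected step is an at least 1.2-fold lower number from compound 2 to compound 4 (0.09 log units; that floor lies within the scatter), resting on an at least 1.3-fold lower number from compound 1 to compound 3 (0.11 log units; that floor lies within the scatter). For compound 4 the estimated value is 8000 nM.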

Compound 4, half-maximal inhibitory concentration: 3200 nM
Compound 4: middle estimate off by 2.5-fold (0.40 log units), on the high side; the measured number falls inside the stated range.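

In this assay, putting 1-(3-hydroxypropyl)-1H-1,2,3-triazol-5-yl in place of ethynyl on the longer chain gives an at least 3.1-fold lower number from compound 2 to compound 4 (0.49 log units; beyond the scatter), a step beyond the scatter. Set beside the same change on the shorter chain, the two steps cannot be ranked: the same change on two cores in this assay, an at least 1.3-fold lower number (0.11 log units; that floor lies within the scatter) from compound 1 to compound 3 and an at least 3.1-fold lower number (0.49 log units; beyond the scatter) from compound 2 to compound 4; the limit leaves it open whether they differ
So the data do not show that the change works better on one core than on the other, because both starting compounds give only a limit: the limit of > 10000 nM in this assay, at which 2 of the 4 values shown sit.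

The compounds shown leave open whether a still longer chain would carry the same step. Also open, on these data alone, is what an amine or a carboxylic acid would do in place of the hydroxy group of the 3-hydroxypropyl chain.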